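The source may report more compounds than this note shows. Statements on the series, on what has been measured and on what is new or still open speak of the compounds shown alone.

Measured compounds in an assay on HEK293 cells for displacement of a labelled ligand from Melanocortin receptor 4 (Homo sapiens); a higher number here means a weaker inhibitor, a lower number a stronger inhibitor:
- compound 1 `CC(C)[C@H](NC(=O)CCN(C)C)c1cccc(F)c1N1CCN(C(=O)[C@@H]2CN(C(C)C)C[C@H]2c2cc(F)c(F)c(F)c2)CC1` gives 250 nM
- compound 2 `Cc1ccc(N2CCN(C(=O)[C@@H]3CN(C4CCOCC4)C[C@H]3c3ccc(Cl)cc3)CC2)c([C@@H](NC(=O)CN)C(C)C)c1` gives 2 nM
- compound 3 `CC(C)[C@H](NC(=O)CCN(C)C)c1cccc(F)c1N1CCN(C(=O)[C@@H]2CN(C(C)C)C[C@H]2c2cc(F)ccc2F)CC1` gives 2050 nM

Compound 1 stands second highest of the three numbers in this assay; compound 3 sits nearest to it with a higher number, and compound 2 lies furthest away with a much lower number. Within the data shown here, compound 2 differs from compound 1 in several places at once, so its value shows only that the shared core can reach a far lower number.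

The step that follows leads to compound 4 `CC(C)[C@H](NC(=O)CCN(C)C)c1cccc(F)c1N1CCN(C(=O)[C@@H]2CN(C(C)C)C[C@H]2c2cc(F)cc(F)c2)CC1`, which differs from compound 1 in one place: hydrogen in place of fluoro on an aromatic carbon. Cut one bond further out, this reads 3,4,5-trifluorophenyl to 3,5-difluorophenyl.

Among the measured compounds shown here, the only measured step that bears on this change is an 8.2-fold higher number from compound 1 to compound 3 (0.91 log units; beyond the scatter), where a different fluorine pattern on the same saturated ring carbon raised the number. That step rearranged the fluoro groups rather than removing one, so it points in direction but not in size. Compound 4 keeps two of the three fluoro groups in place, and a smaller rise than in that step is therefore expected, giving a 2.0-fold higher number from compound 1 to compound 4 (0.30 log units; within the scatter). On this basis compound 4 is estimated at 500 nM in this assay, with a range from 150 nM to 1800 nM.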

Compound 4, inhibition constant: 7800 nM
The estimate for compound 4 lay 16-fold (1.19 log units) below the measured number, outside the stated range (above it).
By their numbers in this assay, from the lowest: compound 2; then compound 1; then compound 3; then compound 4.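

In this assay, the fluoro group ortho to two fluoro groups and para to a large group carries more weight than compound 3 alone suggested: removing it gives a 31-fold higher number from compound 1 to compound 4 (1.49 log units; beyond the scatter), a larger rise than an 8.2-fold higher number from compound 1 to compound 3 (0.91 log units; beyond the scatter). The two difluorophenyl compounds also differ from each other, with a 3.8-fold higher number from compound 3 to compound 4 (0.58 log units; beyond the scatter), so the placement of the fluoro groups matters here and not only their number, and the 3,5-difluorophenyl pattern gives the higher number of the pair. Nothing available explains why this one fluoro group counts for so much.

The compounds shown leave open whether a nitrile or a methoxy group in this place would keep the number of compound 1 or raise it. They also leave open whether the same change would have a similar size in the setting of compound 2, which differs from compound 1 in several places.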